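Replacing an anilino group by pyrrolidine on a quinone-like core

The source may hold more compounds than are shown below. What is called first, only, known or untested is meant among the compounds shown, and "the series" means these compounds.

The compounds share a core carrying an amine substituent; compound 1 is `O=C1C(Nc2cccc(Cl)c2)=CC(=O)c2c1nc1n2[C@H]2OC[C@@H](O)[C@H]2OC1`, compound 2 is `O=C1C=C(Nc2ccc(C(F)(F)F)cc2)C(=O)c2c1nc1n2[C@H]2OC[C@@H](O)[C@H]2OC1`, compound 3 is `O=C1C=C(NC2CCCCC2)C(=O)c2c1nc1n2[C@H]2OC[C@@H](O)[C@H]2OC1` and the unmeasured compound 4 is `O=C1C(N2CCCC2)=CC(=O)c2c1nc1n2[C@H]2OC[C@@H](O)[C@H]2OC1`. Among the compounds with values here, in a functional assay on HeLa cells (Homo sapiens) for inhibition, read by sulforhodamine B assay (on this read-out lower numbers stand for stronger inhibition and higher numbers for weaker inhibition), compound 1 gives 7970 nM, the only value reported as a number among the three measured compounds. Compound 2 reaches only a limit of this assay, > 8000 nM. Compound 3 likewise reaches only a limit, > 16000 nM. Within the data shown here, the single measured step, a step that the two limits leave unreadable from compound 2 to compound 3, is therefore unreadable in size, as the two values rest on the limit of > 8000 nM in this assay, at which 1 of the 3 values shown sits, and (the limit of > 16000 nM in this assay, at which 1 of the 3 values shown sits). The change to compound 4 is pyrrolidin-1-yl in place of (3-chlorophenyl)amino on a double-bonded ring carbon. Among the measured compounds shown here, no measured step in this assay bears readably on it; compound 3, whose amine carries a non-aromatic ring, sits at a limit, and compound 4 also carries a non-aromatic ring on its nitrogen. The step from compound 1 to compound 4 is expected to be a weakening of about a 1.9-fold higher number from compound 1 to compound 4 (0.27 log units; within the scatter), with a fair chance that only a limit is reported. Compound 4 is estimated at 15000 nM, between 4000 nM and 45000 nM.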

Compound 4, half-maximal inhibitory concentration: > 16000 nM
Compound 4 gave a limit, no number; the forecaster's own chance of this, stated with the estimate: 55%; middle value at least 1.0-fold (0.02 log units) away from the limit.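

In this assay, within the data shown here, pyrrolidin-1-yl in place of (3-chlorophenyl)amino on a double-bonded ring carbon gives an at least 2.0-fold higher number from compound 1 to compound 4 (0.30 log units; that floor lies within the scatter) as the first readable step in this set. Even so, this step is only a floor, and the floor lies within the scatter, so it does not establish a real weakening; it rests on a limit rather than a number: the limit of > 16000 nM in this assay, at which 2 of the 4 values shown sit.

The change removes the six-membered aromatic ring and the hydrogen-bond donor together, and the compounds shown cannot separate the two. As far as these compounds go, how far the true value of compound 4 lies from that of compound 1 remains open. So does the question of whether a methyl(phenyl)amino group, which keeps the aromatic ring without the donor, or a morpholin-4-yl group on the same carbon would give a number at all.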